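Cytotoxicity notes: acetyl in place of tert-butyl

This account rests on a few compounds, and the source may have more. Where it says the series, first, only, none or still open, it means among the compounds named here.

Going by the values given here, in an ADME assay on BJ cells (Homo sapiens) for cytotoxicity, with a stated time of 72 h (a higher number here means that more compound is needed for the effect, a lower number that less compound is needed), compound 1 `Cc1cc(NC(=O)Nc2ccc(C(C)(C)C)cc2)c2ccccc2n1` gives 20000 nM, which is the only actual number so far. Compound 2 `Cc1cc(NC(=O)Nc2ccc(C)c(Cl)c2)c2ccccc2n1` reads > 25000 nM, and this is a limit of the assay, not a number. Among the compounds with values here, no step between two measured compounds is available, so the size of any structural effect remains uncalibrated.

Compound 3 `CC(=O)c1ccc(NC(=O)Nc2cc(C)nc3ccccc23)cc1` keeps the core of compound 1 and carries acetyl in place of tert-butyl on an aromatic carbon, para to a large group: acetyl in place of tert-butyl on an aromatic carbon. No shift beyond the usual scatter is expected in this assay. The expected change is a 1.3-fold higher number from compound 1 to compound 3 (0.10 log units; within the scatter), which would remain within that scatter. For compound 3 the estimated value is 25000 nM, with an expected range of 12000 nM to 50000 nM.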

Compound 3, half-maximal effective concentration: 22000 nM
Compound 3: the middle estimate sits 1.1-fold (0.06 log units) above what was measured, within the range that was stated.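

This step gives the series its first comparison between two measured compounds in this assay, with a 1.1-fold higher number from compound 1 to compound 3 (0.04 log units; within the scatter) for acetyl in place of tert-butyl on an aromatic carbon, para to a large group. At this position, the exchange brings in oxygen, a double bond outside aromatic rings and a hydrogen-bond acceptor, yet the step stays within the scatter. Compound 2 gives a limit, not a number, and the top of the read-out lies close to the values of this series: the limit of > 25000 nM in this assay, at which 1 of the 3 values shown sits.

From the compounds shown here alone, whether an amine or a carboxylic acid at this position would move the number beyond the scatter remains open. Going by these compounds, it is also open whether a longer chain here would leave the read-out as flat as acetyl does.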